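This account rests on a few compounds, and the source may have more. Where it says the series, first, only, none or still open, it means among the compounds named here.

Working notes on the series, all read in a functional assay on L1210 cells (Mus musculus) for inhibition; a lower number here means a stronger inhibitor, a higher number a weaker inhibitor. Compound 1 `C=C1[C@@H](O)[C@H](n2ccc(=O)[nH]c2=O)O[C@@H]1CO` gives > 500000 nM, which is a limit of the assay and not a number. Compound 2 `C=C1[C@H](n2ccc(=O)[nH]c2=O)O[C@H](CO)[C@H]1O` gives > 500000 nM, again a limit. Compound 3 `C=C1[C@@H](O)[C@H](n2cnc3c(O)nc(N)nc32)O[C@@H]1CO` gives > 200000 nM, also a limit. Compound 3 therefore stands at the limit of > 200000 nM in this assay, at which 1 of the 3 values shown sits, while the other two stand at the limit of > 500000 nM in this assay, at which 2 of the 3 values shown sit. For the measured compounds named here, the series so far holds no measured number, and no order among the three can be read from these limits.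

Compound 4 `C=C1[C@@H](O)[C@H](n2cnc3c(S)nc(N)nc32)O[C@@H]1CO` departs from compound 3 at a single place: sulfanyl in place of hydroxy on an aromatic carbon. Going by the values given here, no measured step gauges this change, so its size in this assay is a judgement and remains uncertain. The step expected, towards stronger inhibition, is an at least 10-fold lower number from compound 3 to compound 4 (1.00 log units; beyond the scatter). A further limit also remains possible. The estimated value for compound 4 is 20000 nM, with an expected range from 2000 nM to 200000 nM.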

Compound 4, half-maximal inhibitory concentration: 207000 nM
The estimate for compound 4 lay 10-fold (1.01 log units) below the measured number; measured number above the stated range.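

For the compounds shown here, no step from compound 3 to compound 4 can be read in this assay. Compound 3 gives > 200000 nM, which is a limit and not a number. The compounds shown leave open how far, if at all, sulfanyl in place of hydroxy on an aromatic carbon shifts inhibition.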